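Cytotoxicity of a furan-to-trifluoromethoxyphenyl swap in skin cells

This account rests on a few compounds, and the source may have more. Where it says the series, first, only, none or still open, it means among the compounds named here.

Compound 1 `CC(C)N(Cc1cccc(OCCCCCC(=O)O)c1)C(=O)c1ccc(-c2ccoc2)cc1`: > 26000 nM
Compound 2 `CCOC(=O)CCCCCOc1cccc(CN(C(=O)c2ccc(-c3ccoc3)cc2)C(C)C)c1`: > 26000 nM

Both measured compounds were tested in an ADME assay on BJ cells (Homo sapiens) for cytotoxicity, read by CellTiter-Glo and resazurin assay, with a stated time of 72 h; a higher number here means that more compound is needed for the effect, a lower number that less compound is needed. Compound 1 gives > 26000 nM, which is a limit of the assay rather than a number. Compound 2 gives > 26000 nM, also a limit. The change between them, ethyl in place of hydrogen on an oxygen next to a carbonyl group, therefore yields a step that the two limits leave unreadable from compound 1 to compound 2. Compound 2 thus stands at the limit of > 26000 nM in this assay, at which 2 of the 2 values shown sit, with no measured value that places it more precisely.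

Compound 3 `CCOC(=O)CCCCCOc1cccc(CN(C(=O)c2ccc(-c3cccc(OC(F)(F)F)c3)cc2)C(C)C)c1` differs from compound 2 by 3-(trifluoromethoxy)phenyl in place of furan-3-yl on an aromatic carbon. Within the data shown here, no measured step bears on this change, and the single step available is unreadable, so there is nothing to point toward a direction. Compound 3 is expected to sit at the same limit, with an estimated step of a number no higher from compound 2 to compound 3 (the limit leaves the size open). The estimated value of compound 3 is 26000 nM, between 8000 nM and 60000 nM.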

Compound 3, half-maximal effective concentration: > 26000 nM
Compound 3 ended at the assay's limit; the forecaster's own chance of this, stated with the estimate: 65%; the middle value sits exactly at the limit.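

The results for compound 2 and compound 3 are both limits rather than numbers, so the step between them cannot be read: the limit of > 26000 nM in this assay, at which 3 of the 3 values shown sit. The compounds shown leave open at what concentration any of them would affect these cells, and whether either single change alters that concentration.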